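This account rests on a few compounds, and the source may have more. Where it says the series, first, only, none or still open, it means among the compounds named here.

Series notes. Compound 1 `COc1cccc(Nc2cc3[nH]c(-c4cccc(C(F)(F)F)c4)nc3cn2)n1`, compound 2 `COc1ccnc(Nc2cc3[nH]c(-c4cccc(C(F)(F)F)c4)nc3cn2)c1` and compound 3 `FC(F)(F)c1cccc(-c2nc3cnc(Nc4cnccn4)cc3[nH]2)c1` share one core and differ only in the aromatic ring carried on the amine nitrogen. In a physicochemical assay for solubility, using the shake flask method, measured as kinetic solubility, with a stated time of 20 h, at pH 2 (on this read-out lower numbers stand for lower solubility and higher numbers for higher solubility), compound 1 gives 85000 nM and compound 3 gives 155000 nM. For compound 2 this assay reports only a limit, < 5000 nM (the limit of < 5000 nM in this assay, at which 1 of the 3 values shown sits). Among the numbers shown, compound 3 stands highest, with compound 1 nearest: a 1.8-fold higher number from compound 1 to compound 3 (0.26 log units; within the scatter). The two methoxypyridinyl rings lie far apart in this assay: an at least 17-fold lower number from compound 1 to compound 2 (1.23 log units; beyond the scatter), and against the pyrazinyl ring an at least 31-fold higher number from compound 2 to compound 3 (1.49 log units; beyond the scatter).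

Compound 4 `NC(=O)c1ccc(Nc2cc3[nH]c(-c4cccc(C(F)(F)F)c4)nc3cn2)nc1` is not yet measured; its change from compound 3 is 5-carbamoylpyridin-2-yl in place of pyrazin-2-yl on a nitrogen on an aromatic ring. Among the measured compounds shown here, no measured step carries a carbamoyl group, so only the pyridin-2-yl exchanges bear on it: one exchange of pyrazin-2-yl for a pyridin-2-yl ring stayed within the scatter, the other reached the limit. The step of a 3.1-fold lower number from compound 3 to compound 4 (0.49 log units; beyond the scatter) is therefore expected to be a moderate fall with wide uncertainty. Compound 4 is estimated at 50000 nM, between 5000 nM and 200000 nM.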

Compound 4, solubility: < 5000 nM
Compound 4 gave a limit, no number; the forecaster's own chance of this, stated with the estimate: 25%; middle value at least 10-fold (1.00 log units) from the limit.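

Compound 4 gives a limit and not a number in this assay, so a limit at this position is not tied to a methoxy group: the limit of < 5000 nM in this assay, at which 2 of the 4 values shown sit.

The change to 5-carbamoylpyridin-2-yl gives an at least 31-fold lower number from compound 3 to compound 4 (1.49 log units; beyond the scatter), and the same ring set against the 6-methoxypyridin-2-yl ring gives an at least 17-fold lower number from compound 1 to compound 4 (1.23 log units; beyond the scatter). A pyridin-2-yl ring on this nitrogen therefore does not fix the outcome by itself, as compound 1 keeps a number while compound 2 and compound 4 do not, and the step between those last two cannot be read.

On these data alone, how much of the step belongs to the carbamoyl group and how much to the ring itself remains open. An unsubstituted pyridin-2-yl ring, or a carboxylic acid in place of the carbamoyl group, would bear on that.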